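Shortening the amide link in a three-compound antiproliferative set

The compounds below may be only part of what the source reports. "The series", "measured", "known", "first", "only" and "open" are said of these compounds alone.

Measured so far in a functional assay on HepG2 cells (Homo sapiens) for antiproliferative activity, read by CCK-8 assay, with a stated time of 72 h, tested at 2 uM; a higher number here means a stronger effect of the compound at the concentration tested, a lower number a weaker effect:
compound 1 `Nc1ccccc1NC(=O)/C=C/c1ccc(Cn2cnc3c(Nc4cccc(OC(F)(F)F)c4)nc(Cl)nc32)cc1` gives 16.2%
compound 2 `CCCCn1cnc2c(Nc3ccccc3)nc(NCOCc3ccc(/C=C/C(=O)Nc4ccccc4N)cc3)nc21` gives 27.9%
compound 3 `Nc1ccccc1NC(=O)c1ccc(Cn2cnc3c(Nc4cccc(OC(F)(F)F)c4)nc(Cl)nc32)cc1` gives 1.88%

Compound 2 stands highest of the three, its gap to compound 1 and its larger gap to compound 3 both beyond the scatter. Compound 1 and compound 2 carry different cores; how the two cores differ is not broken down here.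

Within the core of compound 1, one change is documented: (2-aminophenyl)carbamoyl in place of 2-((2-aminophenyl)carbamoyl)ethenyl on an aromatic carbon. This step gives a number 14.3 percentage points lower from compound 1 to compound 3 (beyond the scatter), a modest fall that nonetheless exceeds the scatter.

The unmeasured compound 4 `CCCCn1cnc2c(Nc3ccccc3)nc(NCOCc3ccc(C(=O)Nc4ccccc4N)cc3)nc21` relates to compound 2 exactly as compound 3 relates to compound 1: (2-aminophenyl)carbamoyl in place of 2-((2-aminophenyl)carbamoyl)ethenyl on an aromatic carbon. The place descriptions agree word for word, so this is the same change carried onto the core of compound 2, with no further alteration.

Going by the values given here, with only one prior instance, the expectation for compound 4 rests on that single step. Compound 4 is expected to fall from compound 2 by about the same amount, an estimated a number 13.9 percentage points lower from compound 2 to compound 4 (beyond the scatter), since the same change in compound 1 gave a number 14.3 percentage points lower from compound 1 to compound 3 (beyond the scatter). Among the compounds with values here, compound 4 is therefore estimated at 14%, with a likely range of 3% to 25%, the width reflecting the single precedent and the ordinary scatter of this read-out.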

Compound 4, a percentage reported as inhibition, at one concentration (the size of the read-out at that concentration, not a potency): 46.6%
Compound 4: the middle estimate sits 32.6 percentage points below what was measured, and the stated range ends below it.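

In this assay, replacing 2-((2-aminophenyl)carbamoyl)ethenyl with (2-aminophenyl)carbamoyl on the core of compound 2 gives a number 18.7 percentage points higher from compound 2 to compound 4 (beyond the scatter), so the shorter group does not bring a fall here and the direction of the earlier step does not carry over. Set side by side, the two steps run in opposite directions, and the change therefore cannot be treated as transferable between these two cores: the same change on two cores in this assay, a number 14.3 percentage points lower (beyond the scatter) from compound 1 to compound 3 and a number 18.7 percentage points higher (beyond the scatter) from compound 2 to compound 4, 33 percentage points apart, beyond the scatter of two such steps

This shows that the outcome of the change depends on the core within these two pairs, but it does not show which of the several differences between the cores decides the direction, and two pairs read at a single concentration give no rule for the wider series.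

Still open, as far as these compounds go, is which part of the core reverses the step, a question that cores differing from compound 1 or compound 2 in only one place could address. Also open, from the compounds shown here alone, is how the read-out responds when a saturated chain takes the place of the ethenyl link, or when a hydroxamic acid takes the place of the 2-aminophenyl amide on either core.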